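Aromatic substituent variation on a shared dihydrotriazine-bearing core

The source may report more compounds than this note shows. Statements on the series, on what has been measured and on what is new or still open speak of the compounds shown alone.

Measured compounds:
compound 1 `CC1(C)N=C(N)N=C(N)N1c1cccc(C(O)c2ccccc2)c1`: 6.41
compound 2 `CC1(C)N=C(N)N=C(N)N1c1cccc(OCCOc2ccccc2)c1`: 7.34
compound 3 `CC1(C)N=C(N)N=C(N)N1c1cccc(C2CCCCC2)c1`: 7.97

In a functional assay on L5178Y cells (Mus musculus) for inhibition (on this read-out higher numbers stand for higher potency (the scale is a negative logarithm) and lower numbers for lower potency), compound 2 stands second highest of the three, with compound 3 higher by a number 1.56 log units higher from compound 1 to compound 3 (beyond the scatter) read from compound 1; against compound 2, compound 3 is higher and compound 1 lower, both beyond the scatter. Compound 4 `CCCCCCCCCOc1cccc(N2C(N)=NC(N)=NC2(C)C)c1` differs from compound 2 in one place: heptyl in place of phenoxy on a saturated chain carbon, two bonds along the chain from an oxygen on an aromatic ring. For the measured compounds named here, no measured step matches this change. Going by the values given here, the one step measured, from compound 1 to compound 3, is large and goes toward a group without oxygen and without a second aromatic ring; compound 2 already lies between those two. A modest rise, within the range set by compound 2 and compound 3, is therefore expected: a number 0.36 log units higher from compound 2 to compound 4 (beyond the scatter). The estimate for compound 4 is 7.7, between 7.1 and 8.3.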

Compound 4, logarithm of the reciprocal of the active concentration, log(1/C): 6.93
Estimate against measurement, compound 4: 0.77 log units above; measured number outside the range, below it.
By their numbers in this assay, from the lowest: compound 1; then compound 4; then compound 2; then compound 3.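

At this chain carbon, in this assay, heptyl in place of phenoxy gives a number 0.41 log units lower from compound 2 to compound 4 (beyond the scatter), so an all-carbon, ring-free group with the same heavy-atom count does not raise the number here. The earlier step of a number 1.56 log units higher from compound 1 to compound 3 (beyond the scatter) therefore does not carry over: losing the oxygen and the aromatic ring went with a rise there and with a fall here. Still open, on these data alone, is whether the phenoxy ring or its oxygen accounts for the difference, and how an amine or a carboxylic acid in place of phenoxy would compare. No measurement given bears on the cause of this fall.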